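The compounds below may be only part of what the source reports. "The series", "measured", "known", "first", "only" and "open" are said of these compounds alone.

Measured compounds in the series:

Compound 1 `CC(C)[C@H](NC(=O)COc1cccc2ccccc12)C(=O)N[C@@H](CC(=O)O)C(=O)CSc1nc(-c2ccccc2)cs1`. In a functional assay on Jurkat cells (Homo sapiens) for inhibition (a higher number here means a weaker inhibitor, a lower number a stronger inhibitor), compound 1 gives > 200000 nM, which is a limit of the assay and not a number.
Compound 2 `CC(C)[C@H](NC(=O)COc1cccc2ccccc12)C(=O)N[C@@H](CC(=O)O)C(=O)CSc1nc2ccccc2o1`. In this assay compound 2 gives > 200000 nM, again a limit.
Compound 3 `CC(C)[C@H](NC(=O)COc1cccc2ccccc12)C(=O)N[C@@H](CC(=O)O)C(=O)CSc1nc2ccccc2[nH]1`. In this assay compound 3 gives > 200000 nM, also a limit.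

Compound 3 therefore stands nowhere in particular on the numbers shown: all three values sit at the same limit, as the limit of > 200000 nM in this assay, at which 3 of the 3 values shown sit, records, and no ranking among the three can be read. The step that the two limits leave unreadable from compound 1 to compound 3 and the step that the two limits leave unreadable from compound 2 to compound 3 are both unreadable for the same reason, and so is the step that the two limits leave unreadable from compound 1 to compound 2; swapping one heteroaryl on the sulfur for another has left every value at the limit.

Compound 4 `CC(C)[C@H](NC(=O)COc1cccc2ccccc12)C(=O)N[C@@H](CC(=O)O)C(=O)COc1ccccn1` carries the change ((pyridin-2-yl)oxy in place of (1H-benzimidazol-2-yl)sulfanyl on a saturated chain carbon bound to a carbonyl carbon). Among the measured compounds shown here, the measured steps that touch this position all ran between compounds that sit at the limit, so they give no readable size and no direction; they say only that varying the group on this chain carbon has not yet produced a measurable inhibitor. The expectation for compound 4 in this assay is accordingly a step that the limit leaves unreadable from compound 3 to compound 4, that is, no movement that can be read, with the result most probably again a limit. Compound 4 is estimated at 300000 nM, with a range from 40000 nM to 2000000 nM.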

Compound 4, half-maximal inhibitory concentration: > 200000 nM
Compound 4 was reported as a limit; the forecaster's own chance of this, stated with the estimate: 85%; the middle value is on the limit's open side.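

In this assay compound 4 gives > 200000 nM as a limit of the assay and not a number. No new step can be read between compound 4 and compound 1, compound 2 or compound 3, and all four compounds share one limit: the limit of > 200000 nM in this assay, at which 4 of the 4 values shown sit.

The compounds shown leave open whether any group on the saturated chain carbon bound to a carbonyl carbon gives a readable value in this assay at all.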